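Solubility at acidic pH: oxan-4-yl for pyrrolidin-3-yl

The source may hold more compounds than are shown below. What is called first, only, known or untested is meant among the compounds shown, and "the series" means these compounds.

Among the compounds with values here, in a physicochemical assay for solubility, at pH 2 (a lower number here means a less soluble compound, a higher number a more soluble compound), compound 2 `Nc1nc(NC2CCNC2)c2sc(-c3ccc(C(F)(F)F)cc3)cc2n1` gives 155 ug/mL, the only number recorded in the set. Compound 1 `CNc1nc(NC2CCOCC2)c2sc(-c3ccc(C(F)(F)F)cc3)cc2n1` reports only a limit in this assay, < 5 ug/mL, which is the limit of < 5 ug/mL in this assay, at which 1 of the 2 values shown sits. Compound 3 `Nc1nc(NC2CCOCC2)c2sc(-c3ccc(C(F)(F)F)cc3)cc2n1` differs from compound 2 by oxan-4-yl in place of pyrrolidin-3-yl on a nitrogen on an aromatic ring. Compound 1 also carries oxan-4-yl on that nitrogen. The step of a 19-fold lower number from compound 2 to compound 3 (1.29 log units; beyond the scatter) is expected to be a fall well beyond the scatter. Compound 3 is estimated at 8 ug/mL, with a range of 2 ug/mL to 40 ug/mL.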

Compound 3, solubility: < 5 ug/mL
Compound 3 was reported as a limit; the forecaster's own chance of this, stated with the estimate: 45%; middle value at least 1.6-fold (0.20 log units) away from the limit.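

Oxan-4-yl in place of pyrrolidin-3-yl on a nitrogen on an aromatic ring now stands as a single change in this assay, with an at least 31-fold lower number from compound 2 to compound 3 (1.49 log units; beyond the scatter). Compound 3 gives < 5 ug/mL, which is a limit and not a number. The step of hydrogen in place of methyl on that nitrogen cannot be read: the limit of < 5 ug/mL in this assay, at which 2 of the 3 values shown sit.

Open, as far as these compounds go, is whether the ring nitrogen of pyrrolidin-3-yl is what matters at this position; piperidin-4-yl, an open-chain amine or a carboxylic acid there would bear on that. From the compounds shown here alone, how far compound 1 and compound 3 lie beyond their limits also stays open.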